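A few compounds are considered here, and "the series" means these few. Any claim that something is new, unique, unknown or untested is made for them only; others in the source may bear on it.

Compounds measured so far:
compound 1, `Cc1cc(Nc2cc(-c3ccccc3)[nH]n2)n2nc(SCc3ccc([N+](=O)[O-])cc3)nc2n1`, with 4250 nM in a functional assay on MGC-803 cells (Homo sapiens) for inhibition, read by MTT assay, with a stated time of 72 h; on this read-out higher numbers stand for weaker inhibition and lower numbers for stronger inhibition;
compound 2, `Cc1cc(Nc2cc(-c3ccccc3)[nH]n2)n2ncnc2n1`, with 21700 nM;
compound 3, `Cc1cc(Nc2cc(-c3ccccc3)[nH]n2)n2nc(SCc3c(Cl)cccc3Cl)nc2n1`, with 5280 nM.

Compound 3 stands second highest of the three numbers. Its nearest neighbour is compound 1, with a difference that is within the scatter, shown by a 1.2-fold higher number from compound 1 to compound 3 (0.09 log units; within the scatter); its furthest is compound 2, reached by a 4.1-fold lower number from compound 2 to compound 3 (0.61 log units; beyond the scatter). The other step among the measured compounds, a 5.1-fold higher number from compound 1 to compound 2 (0.71 log units; beyond the scatter), points the same way: removing the whole (4-nitrobenzyl)sulfanyl group costs potency, while swapping one aryl ring for another within that group changes little.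

Compound 4, `Cc1cc(Nc2cc(-c3ccccc3)[nH]n2)n2nc(SCc3csc4ccccc34)nc2n1`, is not yet measured. It differs from compound 3 in one place: 1-benzothiophen-3-yl in place of 2,6-dichlorophenyl on a saturated chain carbon bound to a sulfur. The step that bears on it most directly is a 1.2-fold higher number from compound 1 to compound 3 (0.09 log units; within the scatter), which shows that exchanging the aryl ring on the saturated chain carbon bound to a sulfur left the number within the scatter. Among the compounds with values here, no measured step shows a fused bicyclic group at this position, so the expectation rests on that single exchange. Compound 4 is therefore expected to differ from compound 3 by a 1.2-fold lower number from compound 3 to compound 4 (0.07 log units; within the scatter), a step not beyond the scatter. The estimated value for compound 4 in this assay is 4500 nM, within a range of 2000 nM to 10000 nM.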

Compound 4, half-maximal inhibitory concentration: 2280 nM
Compound 4: the middle estimate sits 2.0-fold (0.30 log units) above what was measured; the measured number falls inside the stated range.
By their numbers in this assay, from the lowest: compounds 4, 1 and 3 (each within the scatter of the next, the first and the last beyond it); then compound 2.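

In this assay, within the data shown here, the aryl group on the saturated chain carbon bound to a sulfur now proves able to move the number, since 1-benzothiophen-3-yl in place of 2,6-dichlorophenyl gives a 2.3-fold lower number from compound 3 to compound 4 (0.36 log units; beyond the scatter) and this is the first exchange of that group to go beyond the scatter. The same group set against 4-nitrophenyl gives a 1.9-fold lower number from compound 1 to compound 4 (0.27 log units; within the scatter) and stays within the scatter, so 1-benzothiophen-3-yl is set apart from only one of the two single-ring groups, while the whole ((1-benzothiophen-3-yl)methyl)sulfanyl group in place of hydrogen on an aromatic carbon gives a 9.5-fold lower number from compound 2 to compound 4 (0.98 log units; beyond the scatter) and joins the other two groups at that place in lowering the number. Nothing accompanying these numbers bears on the reason for these differences.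

The compounds shown leave open whether the sulfur of the link matters, which an ether oxygen or an amine nitrogen in its place would test, and whether a longer chain would hold the number. They also leave open whether the ring sulfur of 1-benzothiophen-3-yl counts or only the two fused rings, which naphthalen-1-yl at the same place would separate.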